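The compounds below may be only part of what the source reports. "The series", "measured", "known", "first", "only" and "open" are said of these compounds alone.

Measured so far:
- compound 1 `CC#C[C@@H](Cc1nnn[nH]1)c1ccc(OCc2ccc3sc(F)c(-c4ccccc4C)c3c2)cc1`: 0.367 h
- compound 2 `CC#C[C@@H](Cc1nnn[nH]1)c1ccc(OCc2ccc3scc(-c4ccc(OCCCS(C)(=O)=O)cc4C)c3c2)cc1`: 1.48 h

In an ADME assay on microsomes from liver (Rattus norvegicus) for metabolic stability (a lower number here means that the compound disappears faster, a higher number that the compound lasts longer), compound 1 holds the lower of the two numbers, and the gap up to compound 2 lies beyond the scatter. The two compounds differ in more than one place, so they give no measured guide to a single change. Compound 3 `CC#C[C@@H](Cc1nnn[nH]1)c1ccc(OCc2ccc3sc(C)c(-c4ccccc4C)c3c2)cc1` differs from compound 1 as follows: methyl in place of fluoro on an aromatic carbon. Within the data shown here, with no direct precedent, the expected result in this assay is no step beyond the scatter, in either direction: a 1.1-fold lower number from compound 1 to compound 3 (0.05 log units; within the scatter). For compound 3 the estimated half-life is 0.33 h, with an expected range of 0.15 h to 0.75 h.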

Compound 3, half-life: 0.483 h
Compound 3: the middle estimate sits 1.5-fold (0.17 log units) below what was measured; the measured number falls inside the stated range.
By their numbers in this assay, from the lowest: compounds 1 and 3 (each within the scatter of the next); then compound 2.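

In this assay, methyl in place of fluoro on an aromatic carbon next to the ring sulfur gives a 1.3-fold higher number from compound 1 to compound 3 (0.12 log units; within the scatter). This position of the shared core therefore takes either group without a readable difference in half-life, and both compounds keep the 2-methylphenyl group on the neighbouring ring atom. No measurement on hand bears on the reason for this result.

Still open, as far as these compounds go, is whether an amine, a carboxylic acid or a longer chain at this position would shift the half-life beyond the scatter. From the compounds shown here alone, the effect of hydrogen here also remains open, with the 2-methylphenyl group kept in place.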